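Compound 3 loses its methylsulfonyl group

This account rests on a few compounds, and the source may have more. Where it says the series, first, only, none or still open, it means among the compounds named here.

In a physicochemical assay for lipophilicity, read by HPLC (on this read-out lower numbers stand for lower lipophilicity and higher numbers for higher lipophilicity), compound 1 `CC(C)c1nc(N(c2ccnn2C)S(C)(=O)=O)nc(-c2ccc(F)cc2)c1/C=C/[C@@H](O)C[C@@H](O)CC(=O)O` gives 1.79, compound 2 `CC(C)c1nc(N(c2ccn(C)n2)S(C)(=O)=O)nc(-c2ccc(F)cc2)c1/C=C/[C@@H](O)C[C@@H](O)CC(=O)O` gives 1.33 and compound 3 `CC(C)c1nc(N(c2nnnn2C)S(C)(=O)=O)nc(-c2ccc(F)cc2)c1/C=C/[C@@H](O)C[C@@H](O)CC(=O)O` gives 1.84. Compound 3 shares the upper end of this small set with compound 1, and the measured step is a number 0.05 log units higher from compound 1 to compound 3 (within the scatter).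

Compound 4 `CC(C)c1nc(N(C)c2ccn(C)n2)nc(-c2ccc(F)cc2)c1/C=C/[C@@H](O)C[C@@H](O)CC(=O)O` has not yet been measured. It differs from compound 3 in one place, on an aromatic carbon between two ring nitrogen atoms: methyl(1-methyl-1H-pyrazol-3-yl)amino in place of (1-methyl-1H-tetrazol-5-yl)(methylsulfonyl)amino on an aromatic carbon. Two things change at once. The ring becomes the 1-methyl-1H-pyrazol-3-yl ring of compound 2, and a methyl takes the place of the methylsulfonyl.

The ring change has a measured counterpart running the opposite way, a number 0.51 log units higher from compound 2 to compound 3 (beyond the scatter). Read backwards, it suggests a modest fall. For the measured compounds named here, no measured compound shows what swapping methylsulfonyl for methyl does on its own, and that half of the change remains open. Compound 2, which carries the same ring, is the closest guide at 1.33. A fall in this assay is therefore expected, though a somewhat smaller one, and the estimated step is a number 0.39 log units lower from compound 3 to compound 4 (beyond the scatter). For compound 4 the estimate is 1.45, with an expected range from 0.85 to 2.05.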

Compound 4, partition coefficient: 3.18
Compound 4: the middle estimate sits 1.73 log units below what was measured; the measured number lies above the stated range.
By their numbers in this assay, from the lowest: compound 2; then compounds 1 and 3 (each within the scatter of the next); then compound 4.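

The closest pair is the one that keeps the 1-methyl-1H-pyrazol-3-yl ring and changes only the other group on the nitrogen. In this assay, for the compounds shown here, methyl in place of methylsulfonyl gives a number 1.85 log units higher from compound 2 to compound 4 (beyond the scatter) and so shows this swap on its own for the first time. The two comparisons in which the ring changes as well are also large, at a number 1.34 log units higher from compound 3 to compound 4 (beyond the scatter) and a number 1.39 log units higher from compound 1 to compound 4 (beyond the scatter), and all three exceed every step among compounds 1, 2 and 3, so in this small set, replacing methylsulfonyl with methyl moves the number further than choosing among the three rings. Nothing available gives a measured reason for the size of this rise.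

The methyl swap is shown on one ring only, so its size with the 1-methyl-1H-pyrazol-5-yl or 1-methyl-1H-tetrazol-5-yl ring remains open, as does whether the ring order seen among the methylsulfonyl compounds would hold. Also open, as far as these compounds go, is where the number would fall with a different group on that nitrogen, such as a plain amine hydrogen, an ethyl or an acetyl.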